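This account rests on a few compounds, and the source may have more. Where it says the series, first, only, none or still open, it means among the compounds named here.

Measured compounds:
- Compound 1, `O=C(NO)c1ccc(NCc2nc(-c3ccc(Br)o3)nn2-c2ccccc2)cc1`: 55.8%
- Compound 2, `O=C(NO)c1ccc(NCc2nc(-c3ccc(Br)cc3)nn2-c2ccccc2)cc1`: 54.7%
- Compound 3, `O=C(NO)c1ccc(NCc2nc(-c3cccc(Cl)c3)nn2-c2ccccc2)cc1`: 61.2%

The three compounds share one core and differ only in the group attached to an aromatic carbon of the five-membered ring that holds three nitrogen atoms. In an assay on Sf9 cells for inhibition of protein deacetylase HDAC6 (Homo sapiens), read by fluorescence, with a stated time of 40 min, tested at 100 nM (on this read-out lower numbers stand for less inhibition and higher numbers for more inhibition at the one concentration tested (going by the name of the read-out)), compound 1 stands second highest of the three numbers, with compound 2 nearest at a number 1.1 percentage points lower from compound 1 to compound 2 (within the scatter) and compound 3 furthest at a number 5.4 percentage points higher from compound 1 to compound 3 (within the scatter); both of these steps are within the scatter, so no ordering among the three can be claimed.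

Compound 4, `O=C(NO)c1ccc(NCc2nc(-c3ccc(Cl)cc3)nn2-c2ccccc2)cc1`, has not yet been measured. It differs from compound 1 in one place: 4-chlorophenyl in place of 5-bromofuran-2-yl on an aromatic carbon

Among the measured compounds shown here, two measured steps bear on this change. Exchanging the 5-bromofuran-2-yl group for a six-membered carbon ring gave a number 1.1 percentage points lower from compound 1 to compound 2 (within the scatter) with 4-bromophenyl and a number 5.4 percentage points higher from compound 1 to compound 3 (within the scatter) with 3-chlorophenyl; the step between those two six-membered rings was a number 6.5 percentage points higher from compound 2 to compound 3 (within the scatter). Every one of these stays within the scatter, so the move to 4-chlorophenyl is expected to leave the read-out in this assay essentially unchanged, with no step beyond the scatter in either direction.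

Compound 4 is therefore estimated at 57% in this assay, with a likely range from 46% to 68%. This estimate corresponds to an expected step of a number 1.2 percentage points higher from compound 1 to compound 4 (within the scatter).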

Compound 4, a percentage reported as inhibition, at one concentration (the size of the read-out at that concentration, not a potency): 67.2%
Compound 4: the middle estimate sits 10.2 percentage points below what was measured; the measured number falls inside the stated range.
By their numbers in this assay, from the lowest: compounds 2, 1, 3 and 4 (each within the scatter of the next, the first and the last beyond it).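

In this assay, this position now shows steps beyond the scatter, though modest ones: a number 11.4 percentage points higher from compound 1 to compound 4 (beyond the scatter) with 4-chlorophenyl in place of 5-bromofuran-2-yl, and a number 12.5 percentage points higher from compound 2 to compound 4 (beyond the scatter) with chloro in place of bromo on an otherwise identical phenyl group. Among the compounds shown here, the halogen on the phenyl group can therefore shift the read-out, whereas the earlier steps at this position all stayed within the scatter. The step with 4-chlorophenyl in place of 3-chlorophenyl, a number 6 percentage points higher from compound 3 to compound 4 (within the scatter), is within the scatter, so these two chlorophenyl compounds cannot be ordered, and no measurement at hand gives a reason for any of these steps.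

The compounds shown leave open whether a halogen is needed at all, which a plain phenyl, a methoxyphenyl or an aminophenyl group would test, and whether 5-chlorofuran-2-yl would separate the effect of the ring from that of the halogen. On these data alone, each number also comes from a single concentration, so whether these steps would hold up as differences in potency remains open.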